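The source may hold more compounds than are shown below. What is called first, only, known or untested is meant among the compounds shown, and "the series" means these compounds.

Measured compounds: compound 1 `O=C(Nc1c(C(O)(C(F)(F)F)C(F)(F)F)ccc2ccccc12)C1CCCC1`, compound 2 `O=C(Nc1c(C(O)(C(F)(F)F)C(F)(F)F)ccc2ccccc12)c1cccc(Cl)c1` and compound 3 `O=C(Nc1c(C(O)(C(F)(F)F)C(F)(F)F)ccc2ccccc12)c1cccc(C(F)(F)F)c1`. In an assay on LtK cells with ATP-sensitive inward rectifier potassium channel 11 (Homo sapiens) as the target (a lower number here means that less compound is needed, a higher number that more compound is needed for the effect), compound 1 gives 495 nM, compound 2 gives 98 nM, and compound 3 gives 84 nM.

Compound 3 has the lowest number of the three in this assay; compound 2 is nearest, a 1.2-fold lower number from compound 2 to compound 3 (0.07 log units; within the scatter), and compound 1 furthest, a 5.9-fold lower number from compound 1 to compound 3 (0.77 log units; beyond the scatter). Compound 4 `O=C(Nc1c(C(O)(C(F)(F)F)C(F)(F)F)ccc2ccccc12)c1cccnc1` differs from compound 3 by pyridin-3-yl in place of 3-(trifluoromethyl)phenyl on a carbonyl carbon. The steps of a 5.1-fold lower number from compound 1 to compound 2 (0.70 log units; beyond the scatter) and a 5.9-fold lower number from compound 1 to compound 3 (0.77 log units; beyond the scatter) show that a six-membered aromatic ring on the carbonyl carbon gives a lower number than cyclopentyl, and a 1.2-fold lower number from compound 2 to compound 3 (0.07 log units; within the scatter) shows the choice of substituent on that ring mattered little. Within the data shown here, no measured step replaces the carbon-only ring with a ring holding a hetero atom, so the expected step of a 2.4-fold higher number from compound 3 to compound 4 (0.38 log units; beyond the scatter) is a modest rise. Compound 4 is therefore estimated at 200 nM, between 80 nM and 600 nM.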

Compound 4, half-maximal effective concentration: 60 nM
The estimate for compound 4 lay 3.3-fold (0.52 log units) above the measured number; the whole stated range lies above it.
By their numbers in this assay, from the lowest: compounds 4, 3 and 2 (each within the scatter of the next); then compound 1.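

In this assay, a ring nitrogen on the carbonyl carbon costs nothing measurable: a 1.4-fold lower number from compound 3 to compound 4 (0.15 log units; within the scatter) and a 1.6-fold lower number from compound 2 to compound 4 (0.21 log units; within the scatter) both stay within the scatter, so the unsubstituted pyridin-3-yl stands level with both substituted phenyl rings. The gain over cyclopentyl extends to this ring with a hetero atom, as an 8.3-fold lower number from compound 1 to compound 4 (0.92 log units; beyond the scatter) shows. No evidence at hand explains this result. Still open, as far as these compounds go, is how pyridin-2-yl or pyridin-4-yl would compare at this carbonyl carbon. Also open, from the compounds shown here alone, is whether an amine or a carboxylic acid on the pyridine ring would shift the number.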